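Sulfur-linked chain: ring removed, thioether in its place

The source may hold more compounds than are shown below. What is called first, only, known or untested is meant among the compounds shown, and "the series" means these compounds.

Working notes on the series. The shared core of compound 1, `CC(C)c1n[nH]c2c(NCc3ccc(-c4ccccn4)cc3)nc(SCC3CNC(=O)O3)nc12`, carries a sulfur-linked chain bearing a ring. Going by the values given here, in a functional assay on HT cells (Homo sapiens) for antiproliferative activity, read by fluorescence, with a stated time of 72 h (a lower number here means a stronger inhibitor of growth, a higher number a weaker inhibitor of growth), compound 1 gives 80 nM, the highest of the two numbers measured so far. Compound 2, `CC(C)c1n[nH]c2c(NCc3ccc(-c4ccccn4)cc3)nc(SCCN)nc12`, gives 22 nM. Among the compounds with values here, the single measured step is a 3.6-fold lower number from compound 1 to compound 2 (0.56 log units; beyond the scatter), which shows that loss of the ring at this point of the chain is tolerated and brings a modest gain when aminomethyl enters.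

Compound 3, `CSCCSc1nc(NCc2ccc(-c3ccccn3)cc2)c2[nH]nc(C(C)C)c2n1`, is not yet measured. Relative to compound 1 the change is (methylsulfanyl)methyl in place of 2-oxo-1,3-oxazolidin-5-yl on a saturated chain carbon bound to a sulfur. The step from compound 1 to compound 2 bears on it only in part: the same ring leaves at the same place, but what enters here is (methylsulfanyl)methyl, which lacks the donor that aminomethyl carried. On that basis a step of at most the measured size is expected, more likely smaller, toward a lower number or none beyond the scatter.

Compound 3 is therefore estimated at 55 nM, with a range from 22 nM to 140 nM. The expected step is a 1.5-fold lower number from compound 1 to compound 3 (0.16 log units; within the scatter).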

Compound 3, concentration for 50% growth inhibition: 975 nM
Compound 3: middle estimate off by 18-fold (1.25 log units), on the low side; measured number above the stated range.
By their numbers in this assay, from the lowest: compound 2; then compound 1; then compound 3.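

In this assay, this position on the sulfur-linked chain proves sensitive to what it carries: (methylsulfanyl)methyl in place of 2-oxo-1,3-oxazolidin-5-yl gives a 12-fold higher number from compound 1 to compound 3 (1.09 log units; beyond the scatter), so losing the ring does not bring a gain by itself. The gain seen earlier therefore goes with aminomethyl as the entering group and not with the departure of the ring, as methylsulfanyl in place of amino on a saturated chain carbon, two bonds along the chain from a sulfur, gives a 44-fold higher number from compound 2 to compound 3 (1.65 log units; beyond the scatter) and so places the two acyclic chains far apart in this series. No measurement available here accounts for the size of either step.

The amino to methylsulfanyl step changes both what leaves and what enters, so the compounds shown cannot tell whether the loss of amino or the arrival of methylsulfanyl sets the higher number. Hydroxyl, dimethylamino or a carboxylic acid at the chain end, or a 3-aminopropyl chain in place of the 2-aminoethyl chain, would show how far the result depends on a primary amine at this exact distance from the sulfur.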